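A few compounds are considered here, and "the series" means these few. Any claim that something is new, unique, unknown or untested is made for them only; others in the source may bear on it.

Working notes on the series.

Among the measured compounds shown here, compound 2, `CC(=O)Nc1ccc([C@H](C)NCC2CCN(CCCc3c[nH]c4ccc(-n5cnnc5)cc34)CC2)cc1`, gives 9.3 nM in an assay on CHO cells for displacement of a labelled ligand from 5-hydroxytryptamine receptor 1B (Homo sapiens) (a lower number here means a stronger inhibitor, a higher number a weaker inhibitor), and holds the lowest of the three numbers measured so far. Compound 3, `CN(C1CCN(CCCc2c[nH]c3ccc(-n4cnnc4)cc23)CC1)S(=O)(=O)c1ccccc1`, gives 10 nM in this assay, a reading that sits within the scatter of compound 2. Compound 1, `CC(=O)Nc1ccc(CNC2CCN(CCCc3c[nH]c4ccc(-n5cnnc5)cc34)CC2)cc1`, gives 45 nM in this assay, a reading that lies beyond the scatter from compound 2 and marks compound 1 as the weaker inhibitor of the two.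

Compound 4, `CC(=O)Nc1ccc(CNCC2CCN(CCCc3c[nH]c4ccc(-n5cnnc5)cc34)CC2)cc1`, has not yet been measured. Relative to compound 2 the change is hydrogen in place of methyl on a saturated chain carbon bound to an amine nitrogen and an aromatic carbon. For the measured compounds named here, no measured pair shows this change on its own. Hydrogen at that position is also carried by compound 1, whose reading of 45 nM is the higher one shown, but its chain to the amine is not that of compound 4, so it serves only as a rough pointer.

The expected step is a 2.7-fold higher number from compound 2 to compound 4 (0.43 log units; beyond the scatter) in this assay, a modest move toward a higher number that may reach just beyond the scatter. Compound 4 is estimated at 25 nM, with a range from 9 nM to 70 nM.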

Compound 4, half-maximal inhibitory concentration: 8.9 nM
Compound 4: middle estimate off by 2.8-fold (0.45 log units), on the high side; measured number outside the range, below it.
By their numbers in this assay, from the lowest: compounds 4, 2 and 3 (each within the scatter of the next); then compound 1.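

In this assay, hydrogen in place of methyl on a saturated chain carbon bound to an amine nitrogen and an aromatic carbon gives a 1.0-fold lower number from compound 2 to compound 4 (0.02 log units; within the scatter), so within this pair 1-(4-acetamidophenyl)ethyl and 4-acetamidobenzyl cannot be told apart. The methyl is therefore not required for a reading at this level, and hydrogen at this position does not by itself go with the higher number of compound 1 (45 nM). No supporting data bear on why this change leaves the reading in place.

The compounds shown leave open whether the same carbon accepts a group larger than methyl, such as ethyl or hydroxymethyl, and whether the opposite configuration of the methyl reads like compound 2. This is a single pair, so nothing here carries over to other chains in the series.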